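The source may report more compounds than this note shows. Statements on the series, on what has been measured and on what is new or still open speak of the compounds shown alone.

Three compounds have been measured in an assay on isolated protein for inhibition of Myeloperoxidase (Homo sapiens), read by ELISA, with a stated time of 5 min; a lower number here means a stronger inhibitor, a higher number a weaker inhibitor:

Compound 1 `NC(=O)CCCCc1c[nH]c2ccc(F)cc12` gives 43 nM.
Compound 2 `CNC(=O)CCCc1c[nH]c2ccc(F)cc12` gives 95 nM.
Compound 3 `NC(=O)CCc1c[nH]c2ccc(F)cc12` gives 34 nM.

Compound 3 shows the lowest of the three numbers, but its gap to compound 1, a 1.3-fold lower number from compound 1 to compound 3 (0.10 log units; within the scatter), lies within the scatter; only compound 2 stands clearly apart, a 2.8-fold lower number from compound 2 to compound 3 (0.45 log units; beyond the scatter). Compound 4 `NC(=O)CCCc1c[nH]c2ccc(F)cc12` differs from compound 3 by one change: carbamoylmethyl in place of carbamoyl on a saturated chain carbon, two bonds along the chain from an aromatic carbon. The closest guide is the step from the longer chain of compound 1 to compound 3, a 1.3-fold lower number from compound 1 to compound 3 (0.10 log units; within the scatter), which was within the scatter; compound 4 sits between those two chain lengths. The step is therefore expected to be no larger than the scatter, a 1.2-fold higher number from compound 3 to compound 4 (0.07 log units; within the scatter). Compound 4 is estimated at 40 nM in this assay, in the range 20 nM to 80 nM.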

Compound 4, half-maximal inhibitory concentration: 18 nM
For compound 4 the middle estimate is 2.2-fold (0.35 log units) above the measured one; the measured number lies below the stated range.
By their numbers in this assay, from the lowest: compounds 4, 3 and 1 (each within the scatter of the next, the first and the last beyond it); then compound 2.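

In this assay, the step from carbamoyl to carbamoylmethyl at this position stays within the scatter, a 1.9-fold lower number from compound 3 to compound 4 (0.28 log units; within the scatter), whereas shortening the chain from 2-carbamoylethyl to carbamoylmethyl goes just beyond it, a 2.4-fold lower number from compound 1 to compound 4 (0.38 log units; beyond the scatter). Chain length therefore changes the number only modestly across these compounds. The largest step shown comes instead from hydrogen in place of methyl on the amide-type nitrogen, a 5.3-fold lower number from compound 2 to compound 4 (0.72 log units; beyond the scatter). Nothing available explains these steps. Going by these compounds, whether a carboxylic acid or an amine in place of the carbamoyl group would keep the number this low remains open.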